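Removing the tert-butyl group from a cyanoaziridine urea

The compounds below may be only part of what the source reports. "The series", "measured", "known", "first", "only" and "open" are said of these compounds alone.

Three cyanoaziridine ureas have been measured in a functional assay on MCF7 cells (Homo sapiens) for inhibition; a lower number here means a stronger inhibitor, a higher number a weaker inhibitor. Compound 1 `CCOC(=O)CNC(=O)N1CC1C#N` gives 17000 nM, compound 2 `CCCCNC(=O)N1CC1C#N` gives 6700 nM, and compound 3 `CC(C)(C)NC(=O)N1CC1C#N` gives 190000 nM. Compound 3 thus gives the highest number of the three in this assay; the gap to compound 1 and the step of a 28-fold higher number from compound 2 to compound 3 (1.45 log units; beyond the scatter) both lie beyond the scatter.

Compound 4 `N#CC1CN1C(N)=O` differs from compound 3 by hydrogen in place of tert-butyl on an amide-type nitrogen. Among the measured compounds shown here, no measured pair shows this exact change. For the measured compounds named here, the only step that touches the same nitrogen is a 28-fold higher number from compound 2 to compound 3 (1.45 log units; beyond the scatter), a large rise in number when a branched group replaced a straight chain there. Removing the tert-butyl group altogether is therefore expected to bring the number down from that of compound 3, though probably not as far as compound 2, a moderate step estimated as a 3.8-fold lower number from compound 3 to compound 4 (0.58 log units; beyond the scatter). Compound 4 is accordingly expected to give about 50000 nM in this assay, within a range of 10000 nM to 250000 nM.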

Compound 4, half-maximal inhibitory concentration: > 54000 nM
Compound 4 was reported as a limit; the forecaster's own chance of this, stated with the estimate: 15%; middle value at least 1.0-fold (0.03 log units) away from the limit.
By their numbers in this assay, from the lowest: compound 2; then compound 1; then compound 3.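

In this assay compound 4 gives > 54000 nM, which is a limit and not a number, so the step from compound 3 to compound 4 cannot be read. What can be read is an at least 8.0-fold higher number from compound 2 to compound 4 (0.90 log units; beyond the scatter), so hydrogen on this amide-type nitrogen does not keep the lower number seen with the butyl chain. Until now, the only readable change at this nitrogen was tert-butyl in place of butyl; compound 4 shows that hydrogen in place of butyl also raises the number, a reading that rests on a limit: the limit of > 54000 nM in this assay, at which 1 of the 4 values shown sits.

As far as these compounds go, whether hydrogen gives a higher or a lower number than tert-butyl remains open. The compounds shown also do not tell how a hexyl chain, a benzyl group or a chain ending in an amine on this nitrogen would compare with butyl.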